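A few compounds are considered here, and "the series" means these few. Any claim that something is new, unique, unknown or untested is made for them only; others in the source may bear on it.

Working notes on the series. Compound 1 `CCCS(=O)(=O)Nc1ccc(F)c(C(=O)c2n[nH]c3ncc(-c4ccc(O)cc4)cc23)c1F` gives 0.75% in an assay for binding affinity to dual specificity mitogen-activated protein kinase kinase 4 (Homo sapiens), read by KINOMEscan, tested at 100 nM; a higher number here means a weaker effect of the compound at the concentration tested, a lower number a stronger effect; compound 2 `CCCS(=O)(=O)Nc1ccc(F)c(C(=O)c2n[nH]c3ncc(-c4cc(Cl)cc(Cl)c4)cc23)c1F` gives 73% and so stands highest of the two numbers, separated from compound 1 by the step of a number 72.3 percentage points higher from compound 1 to compound 2 (beyond the scatter). Compound 3 `CCCS(=O)(=O)Nc1ccc(F)c(C(=O)c2n[nH]c3ncc(-c4cccc([N+](=O)[O-])c4)cc23)c1F` is not yet measured. It differs from compound 2 by 3-nitrophenyl in place of 3,5-dichlorophenyl on an aromatic carbon. For the measured compounds named here, the only step bearing on it is that from compound 1 to compound 2, where a change on the same aromatic carbon moved the read-out a great deal. With two acceptors entering, a drop is expected, of size a number 28 percentage points lower from compound 2 to compound 3 (beyond the scatter). Compound 3 is therefore estimated at 45%, within 10% to 85%.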

Compound 3, a percentage reported as activity, at one concentration (the size of the read-out at that concentration, not a potency): 15%
For compound 3 the middle estimate is 30 percentage points above the measured one; low and high end bracket the measured number.
By their numbers in this assay, from the lowest: compound 1; then compound 3; then compound 2.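

In this assay, replacing 3,5-dichlorophenyl with 3-nitrophenyl gives a number 58 percentage points lower from compound 2 to compound 3 (beyond the scatter) and shows that this aromatic carbon still separates two aryl groups that both lack a hydroxyl. Losing the 4-hydroxyphenyl group therefore does not by itself carry the number up to that of compound 2, since the read-out shows only a number 14.3 percentage points higher from compound 1 to compound 3 (beyond the scatter) on this change. Nothing at hand accounts for either step.

From the compounds shown here alone, the two aryl groups differ in both substituent and pattern, so the separate contributions of the nitro group and of the chlorine pattern stay open. Also open, going by these compounds, is how an amine or a carboxylic acid on this phenyl ring would read.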